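This account rests on a few compounds, and the source may have more. Where it says the series, first, only, none or still open, it means among the compounds named here.

Measured so far:
compound 1 `O=C1C(=O)N(Cc2ccc(-c3cccnc3)cc2)c2ccc(OC(F)(F)F)cc21` — 51%
compound 2 `O=C1C(=O)N(Cc2ccc(-c3ccccc3)cc2F)c2ccc(OC(F)(F)F)cc21` — 63%
compound 3 `O=C1C(=O)N(Cc2ccc(-c3ccncc3)nc2)c2ccc(OC(F)(F)F)cc21` — 50%

In a functional assay on CHO cells for positive allosteric modulation of muscarinic acetylcholine receptor M5 (Homo sapiens), read by FLIPR and calcium flux, with a stated time of 1 h (a lower number here means a smaller maximal response, a higher number a larger maximal response), compound 1 gives 51%, the second highest of the three numbers. Compound 3 gives 50%, which lies within the scatter of compound 1. Compound 2 gives 63%, beyond the scatter and higher than compound 1.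

Compound 4 `O=C1C(=O)N(Cc2ccc(Oc3ccccn3)cc2)c2ccc(OC(F)(F)F)cc21` differs from compound 1 in one place: (pyridin-2-yl)oxy in place of pyridin-3-yl on an aromatic carbon. Within the data shown here, no pair of measured compounds isolates this change, so there is no measured step to lean on. The shared core is unchanged, and the nearest measured variations at this position stay close together.

Compound 4 is expected to give 52%, between 38% and 66%. The expected step of a number 1 percentage points higher from compound 1 to compound 4 (within the scatter) is estimated to stay within the scatter, in no clear direction.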

Compound 4, largest response reached (Emax), in percent of the reference or control that the assay uses: 46%
The estimate for compound 4 lay 6 percentage points above the measured number; the measured number falls inside the stated range.
By their numbers in this assay, from the lowest: compounds 4, 3 and 1 (each within the scatter of the next); then compound 2.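

In this assay, (pyridin-2-yl)oxy in place of pyridin-3-yl, on the aromatic carbon para to a large group, gives a number 5 percentage points lower from compound 1 to compound 4 (within the scatter). Among these compounds, this is the first one-place comparison, and it shows that this position takes an oxygen link and a change of pyridine attachment with no step beyond the scatter. Nothing available explains the response at this position. Still open, from the compounds shown here alone, is whether an amine, a carboxylic acid or a longer chain at this position would shift the maximal response. Going by these compounds, the oxygen link with pyridin-3-yl retained also remains open.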